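The compounds below may be only part of what the source reports. "The series", "measured", "known", "first", "only" and "open" are said of these compounds alone.

Compounds measured:

compound 1, `COc1cc(-c2nn(-c3cccc(NC(=O)c4ccc(Cl)c(C(F)(F)F)c4)c3)cc2-c2ccncc2)ccc1Cl`, 1380 nM
compound 2, `COc1cc(-c2nn(-c3cccc(NC(=O)c4cccc(C(F)(F)F)c4)c3)cc2-c2ccncc2)ccc1Cl`, 978 nM
compound 3, `O=C(Nc1cccc(-n2cc(-c3ccncc3)c(-c3ccc(Cl)c(O)c3)n2)c1)Nc1cc(C(F)(F)F)cc(C(F)(F)F)c1`, 600 nM

These three compounds were tested in a functional assay on SK-MEL-5 cells (Homo sapiens) for inhibition, read by sulforhodamine B assay, with a stated time of 48 h; a lower number here means a stronger inhibitor of growth, a higher number a weaker inhibitor of growth. Compound 1 gives the highest of the three numbers. Its nearest neighbour is compound 2, and the step of a 1.4-fold lower number from compound 1 to compound 2 (0.15 log units; within the scatter) lies within the scatter. Among the measured compounds shown here, the furthest is compound 3, whose number is lower than that of compound 1 by a margin beyond the scatter; no single-point step links these two, so only their values can be compared.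

The next compound is compound 4, `COc1cc(-c2nn(-c3cccc(NC(=O)c4ccccc4)c3)cc2-c2ccncc2)ccc1Cl`. It differs from compound 1 as follows: phenyl in place of 4-chloro-3-(trifluoromethyl)phenyl on a carbonyl carbon. For the measured compounds named here, of the measured steps, only the one from compound 1 to compound 2 bears on this change, and it covers just the loss of the chloro; it was small, a 1.4-fold lower number from compound 1 to compound 2 (0.15 log units; within the scatter). Going by the values given here, for the further loss of the trifluoromethyl there is no measured step at all. The expectation for compound 4 is therefore a small step in this assay, most likely toward a higher number, with a wide margin of doubt. Compound 4 is estimated to give 2500 nM, with a range from 900 nM to 7000 nM, a step of a 1.8-fold higher number from compound 1 to compound 4 (0.26 log units; within the scatter).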

Compound 4, concentration for 50% growth inhibition: 319 nM
Compound 4: the middle estimate sits 7.8-fold (0.89 log units) above what was measured; measured number below the stated range.
By their numbers in this assay, from the lowest: compounds 4, 3, 2 and 1 (each within the scatter of the next, the first and the last beyond it).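

Replacing the whole 4-chloro-3-(trifluoromethyl)phenyl with phenyl on the carbonyl carbon gives a 4.3-fold lower number from compound 1 to compound 4 (0.64 log units; beyond the scatter) in this assay, so among these compounds neither substituent is needed for this level of growth inhibition, and the unsubstituted phenyl gives the lowest number of the series on this carbonyl carbon. The two single changes can now be read separately: removing the chloro gives only a 1.4-fold lower number from compound 1 to compound 2 (0.15 log units; within the scatter) and stays within the scatter, while removing the trifluoromethyl gives a 3.1-fold lower number from compound 2 to compound 4 (0.49 log units; beyond the scatter) and is the one of the two that passes beyond it. Nothing at hand gives a measured reason for the lower number with the smaller group.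

The compounds shown leave open how a phenyl carrying the chloro alone would compare with compound 4, and so whether the chloro matters once the trifluoromethyl is gone. They also leave open whether a methoxy or an amine on this phenyl, or a cyclohexyl in its place on the carbonyl carbon, would keep, lower or raise the number in this assay.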